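A few compounds are considered here, and "the series" means these few. Any claim that something is new, unique, unknown or untested is made for them only; others in the source may bear on it.

Compound 1 `CN(C)CCn1cnnc1-c1cc(Oc2ccc(NC(=O)N/N=C/c3c(Cl)cccc3Cl)cc2F)ccn1` in a functional assay on U-87MG ATCC cells (Homo sapiens) for cytotoxicity, read by MTT assay, with a stated time of 72 h (on this read-out higher numbers stand for weaker inhibition and lower numbers for stronger inhibition), gives > 100000 nM, which is a limit of the assay (the limit of > 100000 nM in this assay, at which 1 of the 2 values shown sits).
Compound 2 `CN(C)CCn1cnnc1-c1cc(Oc2ccc(NC(=O)N/N=C/c3ccccc3)cc2F)ccn1` in this assay gives 2250 nM.

Among the compounds with values here, compound 2 holds the only numeric value in this assay; the other entry, for compound 1, is a limit. Within the data shown here, the single measured step, an at least 44-fold lower number from compound 1 to compound 2 (1.64 log units; beyond the scatter), changes the aryl group on a carbon with a double bond to nitrogen. Compound 3 `Cn1cnnc1-c1cc(Oc2ccc(NC(=O)N/N=C/c3ccccc3)cc2F)ccn1` differs from compound 2 elsewhere: hydrogen in place of (dimethylamino)methyl on a saturated chain carbon bound to an aromatic nitrogen. Among the measured compounds shown here, no measured step touches the chain on the aromatic nitrogen, so the change from compound 2 to compound 3 has no precedent among the values shown; the step from compound 1 to compound 2 concerns a different position and does not bear on it. With nothing to anchor a direction, compound 3 is expected to sit near compound 2, an expected step of a 1.6-fold higher number from compound 2 to compound 3 (0.19 log units; within the scatter). The estimate for compound 3 in this assay is 3500 nM, with a range from 1000 nM to 15000 nM.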

Compound 3, half-maximal inhibitory concentration: 36300 nM
Compound 3: middle estimate off by 10-fold (1.02 log units), on the low side; measured number above the stated range.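

The saturated chain carbon bound to an aromatic nitrogen is not a silent position in this assay: hydrogen in place of (dimethylamino)methyl gives a 16-fold higher number from compound 2 to compound 3 (1.21 log units; beyond the scatter). The earlier compounds shown here showed a large change only at the aryl group, with an at least 44-fold lower number from compound 1 to compound 2 (1.64 log units; beyond the scatter), so two separate places now carry steps beyond the scatter. Nothing shown gives a cause for the step at the chain.

As far as these compounds go, it remains open whether the terminal amine or the chain itself carries the difference; a plain propyl chain, a 2-hydroxyethyl chain or a 2-morpholinoethyl chain in place of 2-(dimethylamino)ethyl would separate the two. Also open is whether the two places act independently, since both chains shown here sit on compounds bearing phenyl.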